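The source may hold more compounds than are shown below. What is called first, only, known or untested is meant among the compounds shown, and "the series" means these compounds.

Among the three measured compounds, compound 3 `COc1cc(-c2cnn3cc(OC)c([C@@H]4COC(C)(C)C4)nc23)ccn1` stands with the highest number: in an assay on isolated protein for inhibition of activin receptor type-2A (Homo sapiens), read by 33P incorporation, with a stated time of 20 min, in the presence of a further agent that is not named here (on this read-out lower numbers stand for stronger inhibition and higher numbers for weaker inhibition), compound 3 gives 5300 nM. Compound 2 `COc1cc(-c2cnn3cc(OC)c(C(C)C)nc23)ccn1` gives 3800 nM in this assay, and compound 1 `CNc1nc2c(-c3ccnc(OC)c3)cnn2cc1OC` gives 310 nM. Compound 4 `COc1cc(-c2cnn3cc(OC)c(C4CCCC4)nc23)ccn1` differs from compound 3 by a group of 5 heavy atoms (5 carbon; one five-membered non-aromatic ring of carbon only) in place of a group of 7 heavy atoms (6 carbon, 1 oxygen; one five-membered non-aromatic ring with 1 hetero atom), on an aromatic carbon. The step that bears on this change is a 1.4-fold higher number from compound 2 to compound 3 (0.14 log units; within the scatter), which exchanged a small open-chain group for a ring; the large steps of a 12-fold higher number from compound 1 to compound 2 (1.09 log units; beyond the scatter) and a 17-fold higher number from compound 1 to compound 3 (1.23 log units; beyond the scatter) concern the loss of the methylamino group and say less here. Because the step of a 1.4-fold higher number from compound 2 to compound 3 (0.14 log units; within the scatter) lay within the scatter, no change beyond the scatter is expected for compound 4, giving the estimated step of a 1.3-fold lower number from compound 3 to compound 4 (0.12 log units; within the scatter). Compound 4 is therefore estimated at 4000 nM in this assay, with a range from 1500 nM to 11000 nM.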

Compound 4, half-maximal inhibitory concentration: 2900 nM
Estimate against measurement, compound 4: 1.4-fold (0.14 log units) above, within the range that was stated.
By their numbers in this assay, from the lowest: compound 1; then compounds 4, 2 and 3 (each within the scatter of the next).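

Cyclopentyl, which carries no hydrogen-bond acceptor, gives a 1.8-fold lower number from compound 3 to compound 4 (0.26 log units; within the scatter) in place of the oxygen-containing ring and a 1.3-fold lower number from compound 2 to compound 4 (0.12 log units; within the scatter) in place of isopropyl, so the oxygen-containing ring, isopropyl and cyclopentyl stay close together at this position. Methylamino still stands apart, as cyclopentyl in its place gives a 9.4-fold higher number from compound 1 to compound 4 (0.97 log units; beyond the scatter) on the same core. Nothing measured here gives a reason for these steps.

As far as these compounds go, what remains open is how ethylamino, dimethylamino or an unsubstituted amine at this position would compare with methylamino.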